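Replacing Chloro with Methoxy: an Expected Loss of Potency

The source may hold more compounds than are shown below. What is called first, only, known or untested is meant among the compounds shown, and "the series" means these compounds.

Compound 2 `COc1ccc(CS(=O)(=O)/C=C/c2ccc(Cl)cc2)cc1` was tested in a functional assay on BT-20 cells (Homo sapiens) for antiproliferative activity, read by trypan blue exclusion (a lower number here means a stronger inhibitor, a higher number a weaker inhibitor), and gives 2000 nM. Compound 1 `COc1ccc(/C=C/S(=O)(=O)Cc2ccc(OC)cc2)cc1` reaches only a limit of the assay in this assay, > 20000 nM. The change from compound 2 to compound 1 is methoxy in place of chloro on an aromatic carbon, and it brought an at least 10-fold higher number from compound 2 to compound 1 (1.00 log units; beyond the scatter). The value of compound 1 is the limit of > 20000 nM in this assay, at which 1 of the 3 values shown sits. Compound 3 `COc1ccc(CS(=O)(=O)/C=C/c2ccc(F)cc2Cl)cc1` gives 2500 nM in this assay; the difference between the cores of compound 3 and compound 2 is not broken down here. Compound 4 `COc1ccc(CS(=O)(=O)/C=C/c2ccc(F)cc2OC)cc1` has not yet been measured. It differs from compound 3 by methoxy in place of chloro on an aromatic carbon, the same kind of change as that from compound 2 to compound 1, though here the place is ortho to a large group and meta to a fluoro group rather than para to a large group. Because the earlier change gave an at least 10-fold higher number from compound 2 to compound 1 (1.00 log units; beyond the scatter), a similar weakening is expected, namely a 6.0-fold higher number from compound 3 to compound 4 (0.78 log units; beyond the scatter). Compound 4 is estimated at 15000 nM, between 5000 nM and 40000 nM, with a real chance that only a limit is reported.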

Compound 4, half-maximal inhibitory concentration: 15000 nM
Compound 4: middle estimate and measured number agree at the digits printed; low and high end bracket the measured number.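

In this assay, methoxy in place of chloro on an aromatic carbon again gave a weaker compound, with a 6.0-fold higher number from compound 3 to compound 4 (0.78 log units; beyond the scatter), so the direction of the change held on both cores shown. Whether its size also carried over cannot be said: the same change on two cores in this assay, an at least 10-fold higher number (1.00 log units; beyond the scatter) from compound 2 to compound 1 and a 6.0-fold higher number (0.78 log units; beyond the scatter) from compound 3 to compound 4; the limit leaves it open whether they differ. Compound 1 stands at a limit of the assay, not at a true number: the limit of > 20000 nM in this assay, at which 1 of the 4 values shown sits.

The compounds shown compare only chloro and methoxy in this exchange, and only on two cores. From the compounds shown here alone, how an amine, a carboxylic acid or a longer alkoxy chain in that place would read in this assay remains open, as does whether the same weakening would appear on any further core.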